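The compounds below may be only part of what the source reports. "The series", "measured", "known", "first", "only" and "open" are said of these compounds alone.

Compound 1 `O=C(Cn1cc(CN2C(=O)C(=O)c3c(Cl)ccc(Cl)c32)nn1)NC1CCCCC1` in a toxicity assay on L02 cells (Homo sapiens) for inhibition, read by CCK-8 assay, with a stated time of 72 h (a higher number here means a weaker inhibitor, a lower number a stronger inhibitor), gives 83900 nM and is a weak inhibitor. Compound 2 `O=C1C(=O)N(Cc2cn(CC(=O)N3CCNCC3)nn2)c2c(Cl)ccc(Cl)c21` in this assay returned "nd(insoluble)" (no result reported), no number, and so stands nowhere on the measured scale. Compound 3 `O=C1C(=O)N(Cc2cn(CC(=O)N3CCCC3)nn2)c2c(Cl)ccc(Cl)c21` carries the change (pyrrolidin-1-yl in place of piperazin-1-yl on a carbonyl carbon), that is, pyrrolidin-1-yl in place of piperazin-1-yl on a carbonyl carbon. Among the compounds with values here, with no number for compound 2, no step can be sized from it; the value of compound 1 on the same core is the only anchor, and no shift beyond the scatter of this assay is expected from this ring exchange. Compound 3 is therefore estimated at 80000 nM in this assay, within 30000 nM to 200000 nM.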

Compound 3, half-maximal inhibitory concentration: > 128000 nM
Compound 3 was reported as a limit; the forecaster's own chance of this, stated with the estimate: 30%; middle value at least 1.6-fold (0.20 log units) away from the limit.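

In this assay, compound 3 gives > 128000 nM, which is a limit and not a number. On a carbonyl carbon, pyrrolidin-1-yl in place of cyclohexylamino gives an at least 1.5-fold higher number from compound 1 to compound 3 (0.18 log units; that floor lies within the scatter), so this change shows no firm separation at this position. The position therefore now has a second reading, but no measured order between these two groups.

Steps involving compound 2 cannot be read, so piperazin-1-yl remains unplaced. Going by these compounds, how morpholin-4-yl on the same carbonyl carbon would read in this assay also stays open.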